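A few compounds are considered here, and "the series" means these few. Any claim that something is new, unique, unknown or untested is made for them only; others in the source may bear on it.

Compound 1 `O=S(=O)(Cc1nc(-c2cccs2)c2sccc2n1)c1cccc(Cl)c1`: > 50000 nM
Compound 2 `COc1ccc(-c2nc(C[S+]([O-])c3cccc(Cl)c3)nc3ccsc23)cn1`: > 50000 nM
Compound 3 `COc1ccc(-c2nc(C3(S(=O)(=O)c4cccc(Cl)c4)CC3)nc3ccsc23)cn1`: > 50000 nM

In an ADME assay on cells (Homo sapiens) for cytotoxicity, read by resazurin assay, with a stated time of 5 days (a higher number here means that more compound is tolerated, a lower number that less compound is tolerated), compound 1 reaches only a limit of the assay, > 50000 nM. Compound 2 likewise gives a limit, > 50000 nM. Compound 3 also gives a limit, > 50000 nM. Compound 1 therefore stands at the limit of > 50000 nM in this assay, at which 3 of the 3 values shown sit, and no numbered value sets it apart from the others. Compound 4 `COc1ccc(Nc2nc(CS(=O)(=O)c3cccc(Cl)c3)nc3ccsc23)cc1` is not yet measured. It differs from compound 1 by (4-methoxyphenyl)amino in place of thiophen-2-yl on an aromatic carbon. Among the compounds with values here, no measured pair differs in exactly one place, so no step size is on record. For compound 4 the step expected in this assay is a number no higher from compound 1 to compound 4 (the limit leaves the size open), none beyond the scatter, with the readout expected to stay at the limit. Compound 4 is expected to give 50000 nM, within 20000 nM to 100000 nM.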

Compound 4, half-maximal cytotoxic concentration: 60000 nM
Beside the measured number, compound 4's estimate is 1.2-fold (0.08 log units) below it, within the range that was stated.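

No step from compound 1 to compound 4 can be read, as compound 1 gives only a limit: the limit of > 50000 nM in this assay, at which 3 of the 4 values shown sit.

The compounds shown leave open at what concentration compound 1, compound 2 and compound 3 would reach half-maximal cytotoxicity in this assay.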